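Removing the butylpiperazine from compound 2

The compounds below may be only part of what the source reports. "The series", "measured", "known", "first", "only" and "open" are said of these compounds alone.

Measured in a functional assay on A549 cells (Homo sapiens) for cytotoxicity, read by MTT assay, with a stated time of 72 h (a lower number here means a stronger inhibitor, a higher number a weaker inhibitor), so far
compound 1 `CN(C)CCCCCn1c2c(c3ccccc31)C(=O)c1c[n+]([O-])c3ccccc3c1C2=O` gives 210 nM
compound 2 `CCCCN1CCN(CCCCn2c3c(c4ccccc42)C(=O)c2c[n+]([O-])c4ccccc4c2C3=O)CC1` gives 550 nM

In this assay compound 2, at 550 nM as the higher of just two numbers, is the weaker inhibitor of the pair. The next compound to be tested is compound 3 `O=C1c2c[n+]([O-])c3ccccc3c2C(=O)c2c1c1ccccc1n2CCCCN1CCCCC1` and its change is piperidin-1-yl in place of 4-butylpiperazin-1-yl on a saturated chain carbon, four bonds along the chain from an aromatic nitrogen in a single place. In words, piperidin-1-yl stands in place of 4-butylpiperazin-1-yl on a saturated chain carbon, four bonds along the chain from an aromatic nitrogen.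

For the measured compounds named here, only one measured step bears on this change. It is a 2.6-fold higher number from compound 1 to compound 2 (0.42 log units; beyond the scatter) and it is modest, with 4-butylpiperazin-1-yl in place of (dimethylamino)methyl on a saturated chain carbon. Compound 3 loses that same group but does not regain the group of compound 1, so the evidence is thin. Going by the values given here, no measured step shows piperidin-1-yl itself. A modest move toward a lower number is expected, of about the size of that one step, and the estimated change is a 2.2-fold lower number from compound 2 to compound 3 (0.34 log units; beyond the scatter) in this assay as a rough guide. For compound 3 the expected value is 250 nM within an estimated range of 100 nM to 600 nM in this assay for now.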

Compound 3, half-maximal inhibitory concentration: 150 nM
Compound 3: the middle estimate sits 1.7-fold (0.22 log units) above what was measured; the range from low to high includes it.
By their numbers in this assay, from the lowest: compounds 3 and 1 (each within the scatter of the next); then compound 2.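

Piperidin-1-yl in place of 4-butylpiperazin-1-yl, on a saturated chain carbon, four bonds along the chain from an aromatic nitrogen, gives a 3.7-fold lower number from compound 2 to compound 3 (0.56 log units; beyond the scatter) in this assay, so a cyclic amine at this place can reach the low range that compound 1 had shown with its open-chain dimethylamino end. Piperidin-1-yl in place of (dimethylamino)methyl gives a 1.4-fold lower number from compound 1 to compound 3 (0.15 log units; within the scatter), so compound 1 and compound 3 cannot be told apart here, and among the three compounds only compound 2, with its 4-butylpiperazin-1-yl group, stands apart. Nothing available explains why this one group differs from the other two.

The compounds shown leave open whether the difference belongs to the butyl group or to the piperazine ring itself, a question that 4-methylpiperazin-1-yl or unsubstituted piperazin-1-yl at the same place would help to separate. They also leave open whether the result would hold for morpholin-4-yl or a primary amine at this place, or with a shorter or longer chain.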